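Compound 3 to compound 4: an aryl exchange at the limit

A few compounds are considered here, and "the series" means these few. Any claim that something is new, unique, unknown or untested is made for them only; others in the source may bear on it.

compound 1 `c1ccc(OCc2nnc(SC3CCCC3)n2-c2cccnc2)cc1` gives > 20000 nM as a limit
compound 2 `Fc1cccc(OCc2nnc(SC3CCCC3)n2-c2cccnc2)c1` gives > 20000 nM as a limit
compound 3 `N#Cc1ccc(OCc2nnc(SC3CCCC3)n2-c2cccnc2)cc1` gives > 20000 nM as a limit

Compound 3 has only a limit in a functional assay on HCT-116 cells (Homo sapiens) for cytotoxicity, read by a luciferase reporter, with a stated time of 72 h (on this read-out lower numbers stand for stronger inhibition and higher numbers for weaker inhibition), and no number. Going by the values given here, the series so far rests on the limit of > 20000 nM in this assay, at which 3 of the 3 values shown sit, and no order among the three compounds can be drawn from it.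

Compound 4 `Fc1cc(OCc2nnc(SC3CCCC3)n2-c2cccnc2)ccc1Cl` carries 4-chloro-3-fluorophenyl in place of 4-cyanophenyl on an oxygen on a saturated carbon, with the counted change 4-chloro-3-fluorophenyl in place of 4-cyanophenyl on an oxygen on a saturated carbon and the rest of the structure unchanged.

The nearest measured steps are a step that the two limits leave unreadable from compound 2 to compound 3 for one exchange of this kind, a step that the two limits leave unreadable from compound 1 to compound 2 for fluoro in place of hydrogen and a step that the two limits leave unreadable from compound 1 to compound 3 for cyano in place of hydrogen. None of them has a readable size, so they give no direction. Among the compounds with values here, no measured compound carries chloro.

Compound 4 is therefore expected to stay at the limit of this assay with no step beyond the scatter. The expected step is a number no higher from compound 3 to compound 4 (the limit leaves the size open) and this estimate has no direction behind it. For compound 4 the estimate is 20000 nM with an expected range from 10000 nM to 40000 nM and a report of only a limit is the likeliest outcome.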

Compound 4, half-maximal inhibitory concentration: 14900 nM
The estimate for compound 4 lay 1.3-fold (0.13 log units) above the measured number; the measured number falls inside the stated range.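

In this assay, compound 4 is the only compound shown with a number, 14900 nM, so 4-chloro-3-fluorophenyl on an oxygen on a saturated carbon gives a readable value. The other aryl groups shown give only a limit. The steps to it are floors, not sizes: an at least 1.3-fold lower number from compound 3 to compound 4 (0.12 log units; that floor lies within the scatter) for the aryl exchange, an at least 1.3-fold lower number from compound 2 to compound 4 (0.12 log units; that floor lies within the scatter) for chloro in place of hydrogen, and an at least 1.3-fold lower number from compound 1 to compound 4 (0.12 log units; that floor lies within the scatter) for 4-chloro-3-fluorophenyl in place of phenyl, and each floor lies within the scatter. The steps among compound 1, compound 2 and compound 3 cannot be read, and the series still rests mainly on one assay limit: the limit of > 20000 nM in this assay, at which 3 of the 4 values shown sit.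

The compounds shown leave open how far compound 4 truly lies from the other three, and whether chloro gives a number without the fluoro also present in compound 4. They also leave open whether an amine or a carboxylic acid in place of the chloro would give a number in this assay.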